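This account rests on a few compounds, and the source may have more. Where it says the series, first, only, none or still open, it means among the compounds named here.

Compound 1 `Cc1cc(C)cc(Cn2c(=O)cc(NC3CCCCC3)n(Cc3ccccc3)c2=O)c1` is examined in an ADME assay on MT4 cells (Homo sapiens) for cytotoxicity, read by MTT assay, with a stated time of 4 days (a lower number here means that less compound is tolerated, a higher number that more compound is tolerated), where compound 1 gives 74000 nM. Among the measured compounds shown here, its closest neighbour among the numbers is compound 3 `Cc1cc(C)cc(Cn2c(=O)cc(N=[N+]=[N-])n(Cc3ccncc3)c2=O)c1`, for which compound 3 gives 59000 nM, a figure that lies within the scatter of the one for compound 1. Compound 2 `Cc1cc(C)cc(Cn2c(=O)cc(NCc3ccccc3)n(Cc3ccccc3)c2=O)c1` is recorded in this assay only as a limit, compound 2 giving > 100000 nM. For the measured compounds named here, the one measured step that starts from compound 1 is the exchange of benzyl for cyclohexyl on a nitrogen on an aromatic ring, an at least 1.3-fold higher number from compound 1 to compound 2 (0.13 log units; that floor lies within the scatter), and it rests on (the limit of > 100000 nM in this assay, at which 1 of the 3 values shown sits).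

Compound 4 `Cc1cc(C)cc(Cn2c(=O)cc(N(C)C)n(Cc3ccccc3)c2=O)c1` differs from compound 1 by dimethylamino in place of cyclohexylamino on an aromatic carbon. Going by the values given here, only the step from compound 1 to compound 2 touches that same position, and its floor sits within the scatter, so no shift beyond the scatter is expected for compound 4 in this assay: the expected step is a 1.1-fold higher number from compound 1 to compound 4 (0.03 log units; within the scatter). Compound 4 is therefore estimated at 80000 nM, with a range from 40000 nM to 160000 nM.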

Compound 4, half-maximal cytotoxic concentration: 48000 nM
Estimate against measurement, compound 4: 1.7-fold (0.22 log units) above, and the stated range covers the measured number.
By their numbers in this assay, from the lowest: compounds 4, 3 and 1 (each within the scatter of the next). At a limit, above all of these: compound 2.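

In this assay, among the compounds shown here, replacing benzylamino with dimethylamino on this aromatic carbon gives the first step at this position that lies beyond the scatter (an at least 2.0-fold lower number from compound 2 to compound 4 (0.31 log units; beyond the scatter)). Compound 2 stands only as a limit, so the size of this step is a floor and rests on that limit: (the limit of > 100000 nM in this assay, at which 1 of the 4 values shown sits). Replacing cyclohexylamino with dimethylamino, which removes the six-membered ring and the hydrogen-bond donor, stays within the scatter (a 1.5-fold lower number from compound 1 to compound 4 (0.19 log units; within the scatter)), so the numbers for these two compounds cannot be separated here.

The compounds shown leave open how a primary amine, such as plain amino or methylamino, would read at this carbon. They also leave open whether a longer chain ending in a hydroxyl or a carboxylic acid would shift the number beyond the scatter.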